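A few compounds are considered here, and "the series" means these few. Any claim that something is new, unique, unknown or untested is made for them only; others in the source may bear on it.

Measured so far:
compound 1, `CCCNc1ccc(NC(=O)c2cc(Cl)ccc2O)c(Cl)c1` — 69700 nM in an ADME assay on A549 cells (Homo sapiens) for cytotoxicity, read by LDH release, with a stated time of 15 h; a lower number here means that less compound is tolerated, a higher number that more compound is tolerated
compound 2, `O=C(Nc1ccc(NCCCO)cc1Cl)c1cc(Cl)ccc1O` — "not determined" (no result reported)
compound 3, `O=C(Nc1ccc(NCc2ccc(F)cc2)cc1Cl)c1cc(Cl)ccc1O` — "not determined" (no result reported)

Going by the values given here, compound 1 is the only member of the series with a number in this assay. Compound 3 stands without a single number, and compound 2 likewise carries no result, so no measured step exists between any two compounds here and the position of compound 3 relative to compound 1 cannot be fixed from what is shown. The shared core of compound 1, compound 2 and compound 3 is the same throughout; the three differ only in the group carried on the amino nitrogen.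

Compound 4, `O=C(Nc1ccc(NCc2ccccc2)cc1Cl)c1cc(Cl)ccc1O`, is the next entry. It differs from compound 3 by hydrogen in place of fluoro on an aromatic carbon. This is the removal of one fluorine from the benzyl group, para to a large group, with nothing else touched. Among the compounds with values here, with no measured pair to lean on, the step in this assay from compound 3 to compound 4 is expected to be none beyond the scatter, in neither direction, and the reading for compound 4 is expected near that of compound 1, with a wide range. The estimate for compound 4 in this assay is 60000 nM, between 20000 nM and 150000 nM.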

Compound 4, half-maximal cytotoxic concentration: 81300 nM
Beside the measured number, compound 4's estimate is 1.4-fold (0.13 log units) below it; low and high end bracket the measured number.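

In this assay the series now has its first readable step, a 1.2-fold higher number from compound 1 to compound 4 (0.07 log units; within the scatter), and it puts phenyl in place of ethyl on the saturated chain carbon bound to the nitrogen. Compound 1 and compound 4 therefore read alike, so at this position the propylamino and benzylamino groups cannot be told apart in this read-out, despite the added aromatic ring of compound 4. No measured evidence on the series accounts for this result.

The steps involving compound 2 or compound 3 cannot be read, so the 3-hydroxypropyl chain and the 4-fluorobenzyl group remain unplaced, and the fluoro-to-hydrogen change has no size in this assay. Going by these compounds alone, with only one pair to go on, it remains open whether the same flat reading would hold for a carboxylic acid or a basic dimethylamino group at the end of the chain, for a much longer alkyl chain, or for a methoxy group on the phenyl ring of the benzyl group.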